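Quinone-terpenoid cytotoxicity: stretching a propyl chain to octyl

The compounds below may be only part of what the source reports. "The series", "measured", "known", "first", "only" and "open" are said of these compounds alone.

Of the compounds shown here, three with the shared core have been tested in a functional assay on HeLa cells (Homo sapiens) for cytotoxicity; on this read-out lower numbers stand for stronger inhibition and higher numbers for weaker inhibition. Compound 1 `COC1=CC(=O)C=C(C[C@]2(C)[C@@H](C)CC[C@]3(C)C(C)=CCC[C@@H]23)C1=O` gives 13300 nM. Compound 2 `CCCSC1=CC(=O)C(C[C@]2(C)[C@@H](C)CC[C@]3(C)C(C)=CCC[C@@H]23)=CC1=O` gives 97000 nM, the highest of the two numbers recorded; the nearest value is that of compound 1, a clearly lower number, and the gap between them is beyond the usual scatter. For compound 3 `CC1=CCC[C@H]2[C@](C)(CC3=CC(=O)C4=C(SCCS4)C3=O)[C@@H](C)CC[C@]12C` the assay reports only a limit, > 100000 nM, and not a number; this is the limit of > 100000 nM in this assay, at which 1 of the 3 values shown sits.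

Compound 4 `CCCCCCCCSC1=CC(=O)C(C[C@]2(C)[C@@H](C)CC[C@]3(C)C(C)=CCC[C@@H]23)=CC1=O` is the unmeasured follow-up to compound 2. The difference between them is pentyl in place of hydrogen on a saturated chain carbon, three bonds along the chain from a sulfur; cut one bond further out, the same change reads as propyl to octyl. Within the data shown here, no pair of measured compounds here differs by a single change, so there is no measured step to lean on, and the sole reference point is the value of compound 2 in this assay, which already sits close to the limit at which compound 3 was reported.

The step from compound 2 to compound 4 is expected to be modest, most likely toward a somewhat lower number, a 1.9-fold lower number from compound 2 to compound 4 (0.29 log units; within the scatter). Compound 4 is therefore estimated at 50000 nM in this assay, with a plausible range from 10000 nM to 200000 nM, and a real chance that only a limit is returned.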

Compound 4, half-maximal inhibitory concentration: > 100000 nM
Compound 4 gave a limit, no number; the forecaster's own chance of this, stated with the estimate: 30%; at least 2.0-fold (0.30 log units) between middle value and limit.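

Stretching the chain on sulfur from propyl to octyl brought no measurable gain at this position, the first thing the series shows about chain length here. Read as a step, the change gives an at least 1.0-fold higher number from compound 2 to compound 4 (0.01 log units; that floor lies within the scatter), so a real loss cannot be claimed either, and its size cannot be read. In this assay compound 4 returned a limit and not a number: the limit of > 100000 nM in this assay, at which 2 of the 4 values shown sit.

Open, as far as these compounds go, is whether a shorter chain such as methyl or ethyl on the sulfur, or a propyl chain ending in an amine or a carboxylic acid, would move the number in either direction. Compound 1, which carries a methoxy group in place of the chain on sulfur, gives 13300 nM, but it differs from compound 2 in more than one place, so that lower number cannot be tied to any single change.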